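The source may hold more compounds than are shown below. What is called first, only, known or untested is meant among the compounds shown, and "the series" means these compounds.

In a functional assay on HeLa cells (Homo sapiens) for cytotoxicity, read by MTT assay, with a stated time of 24 h; on this read-out higher numbers stand for weaker inhibition and lower numbers for stronger inhibition:
- compound 1 `COc1ccc(/C=C2\CN(C)C/C(=C\c3ccccc3F)C2=O)cc1OC`: 14400 nM
- compound 2 `COc1cc(/C=C2\CN(C)C/C(=C\c3cc(OC)c(OC)c(OC)c3)C2=O)cc(OC)c1`: 2300 nM

Compound 2 holds the lower number of the two, so it is the stronger inhibitor here, and its gap to compound 1 lies beyond the usual scatter of repeated measurements.

Compound 3 `COc1cc(/C=C2\CN(C)C/C(=C\c3ccc(Cl)c(Cl)c3)C2=O)cc(OC)c1OC` has not yet been measured. It carries 3,4-dichlorophenyl in place of 3,5-dimethoxyphenyl on a double-bonded chain carbon bound to a double-bonded ring carbon.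

Within the data shown here, no two measured compounds differ in just one place, so the data do not show directly what this swap does. The step expected in this assay is a 1.5-fold higher number from compound 2 to compound 3 (0.18 log units; within the scatter), toward a higher number but estimated to stay within the scatter. With so little to go on, the expected range is wide. For compound 3 the estimate is 3500 nM, with an expected range from 900 nM to 13000 nM.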

Compound 3, half-maximal inhibitory concentration: 13500 nM
Beside the measured number, compound 3's estimate is 3.9-fold (0.59 log units) below it, and the stated range ends below it.
By their numbers in this assay, from the lowest: compound 2; then compounds 3 and 1 (each within the scatter of the next).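

Within this assay the swap of 3,5-dimethoxyphenyl for 3,4-dichlorophenyl on a double-bonded chain carbon bound to a double-bonded ring carbon gives a 5.9-fold higher number from compound 2 to compound 3 (0.77 log units; beyond the scatter) and leaves the rest of the molecule unchanged. Among these compounds, this is the first direct reading of this position, and it shows that the group placed there affects the result, with the dichlorophenyl form giving the weaker inhibition. No supporting measurement helps explain this change.

From the compounds shown here alone, this single swap removes the methoxy groups and adds the chlorine atoms at once, so it remains open which of the two changes matters, or whether both do. Going by these compounds, how this position would respond to a phenyl ring carrying an amine or a carboxylic acid also remains unknown.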